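This account rests on a few compounds, and the source may have more. Where it says the series, first, only, none or still open, it means among the compounds named here.

Measured so far in an assay on cells for displacement of a labelled ligand from adenosine receptor A1 (Homo sapiens), read by scintillation counting and radioligand binding, with a stated time of 60 min, tested at 10 uM; a higher number here means more inhibition at the concentration tested (going by the name of the read-out), a lower number less inhibition:
- compound 1 `CN1CCN(c2nc(-c3cccc(O)c3)nc3c2ncn3C)CC1`: 27.1%
- compound 2 `Oc1cccc(-c2nc(N3CCCCC3)c3nc[nH]c3n2)c1`: > 80% (a limit of the assay, not a number)
- compound 3 `CN1CCN(c2nc(-c3cccc(O)c3)nc3[nH]cnc23)CC1`: > 80% (a limit of the assay, not a number)

Compound 3 and compound 1 differ by methyl in place of hydrogen on an aromatic nitrogen. That change gave a number at least 52.9 percentage points lower from compound 3 to compound 1 (beyond the scatter). Since both limiting values rest on (the limit of > 80% in this assay, at which 2 of the 3 values shown sit), the size of the step can only be given as a lower bound.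

Compound 2 and compound 3 differ in their cores by piperidin-1-yl in place of 4-methylpiperazin-1-yl on an aromatic carbon. The step that the two limits leave unreadable from compound 2 to compound 3 cannot be sized, as both values are limits of this assay.

Compound 4 `Cn1cnc2c(N3CCCCC3)nc(-c3cccc(O)c3)nc21` is not yet measured. It differs from compound 2 by methyl in place of hydrogen on an aromatic nitrogen, the same change made from compound 3 to compound 1, at a place described in the same words. Among the compounds with values here, the only measured instance of this change, from compound 3 to compound 1, was large. Compound 2 sits at the same limit as compound 3, so for compound 4 a step of a number at least 50 percentage points lower from compound 2 to compound 4 (beyond the scatter) is expected, resting on a number at least 52.9 percentage points lower from compound 3 to compound 1 (beyond the scatter) having been seen once, on a different core. Compound 4 is therefore estimated at 30%, within 8% to 60%.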

Compound 4, a percentage reported as inhibition, at one concentration (the size of the read-out at that concentration, not a potency): 78.5%
Estimate against measurement, compound 4: 48.5 percentage points below; the measured number lies above the stated range.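

In this assay, methyl in place of hydrogen on the aromatic nitrogen gave a number at least 1.5 percentage points lower from compound 2 to compound 4 (that floor lies within the scatter), so the large fall seen with 4-methylpiperazin-1-yl on the aromatic carbon is not repeated as a readable fall with piperidin-1-yl there. With methyl present in both compounds, the exchange of 4-methylpiperazin-1-yl for piperidin-1-yl gave a number 51.4 percentage points higher from compound 1 to compound 4 (beyond the scatter), so the result of the methyl change on one core cannot simply be carried to the other. The step between compound 2 and compound 3 cannot be read, and whether the two methyl steps truly differ is not shown: the same change on two cores in this assay, a number at least 52.9 percentage points lower (beyond the scatter) from compound 3 to compound 1 and a number at least 1.5 percentage points lower (that floor lies within the scatter) from compound 2 to compound 4; the limit leaves it open whether they differ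

Within the data shown here, only two groups on the aromatic carbon are compared here, which leaves open whether the outcome of the methyl change follows the group at that place more generally. Going by these compounds, how a morpholin-4-yl group on that carbon, or an ethyl group on the aromatic nitrogen, would behave also remains open.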